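Bromo removed from the dihydroxy quinolinone ester series

This account rests on a few compounds, and the source may have more. Where it says the series, first, only, none or still open, it means among the compounds named here.

Measured so far:
Compound 1 `CCOC(=O)CCCn1cc(C#N)c2cc(OC)c(OC)cc2c1=O` — 10000 nM
Compound 2 `CCOC(=O)CCCn1cc(Br)c2cc(O)c(O)cc2c1=O` — 11000 nM

In a functional assay on Jurkat cells (Homo sapiens) for cytotoxicity, read by MTT assay (on this read-out lower numbers stand for stronger inhibition and higher numbers for weaker inhibition), compound 1 gives 10000 nM. In this assay compound 2 gives 11000 nM; compound 2 and compound 1 thus lie within the scatter of each other, and both sit at the weak end of the scale. Going by the values given here, no step between these two measured compounds has been worked out, since they differ in more than one place, so the two values say only that neither compound inhibits Jurkat cell growth strongly.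

The next compound keeps the core of compound 2 and drops the halogen: compound 3 `CCOC(=O)CCCn1ccc2cc(O)c(O)cc2c1=O`. The change is hydrogen in place of bromo on an aromatic carbon.

Among the compounds with values here, with no measured pair that isolates this change, the expectation rests on the two values above. Both stand close to each other, and removal of bromo is not expected to move the number beyond the scatter in either direction; if anything a slightly weaker result is anticipated. The step is estimated at a 1.4-fold higher number from compound 2 to compound 3 (0.13 log units; within the scatter). For compound 3 the estimate in this assay is 15000 nM, with a range of 6000 nM to 40000 nM.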

Compound 3, half-maximal inhibitory concentration: 47000 nM
Beside the measured number, compound 3's estimate is 3.1-fold (0.50 log units) below it; measured number above the stated range.
By their numbers in this assay, from the lowest: compounds 1 and 2 (each within the scatter of the next); then compound 3.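

In this assay the first pair differing in one place gives a 4.3-fold higher number from compound 2 to compound 3 (0.63 log units; beyond the scatter) with the loss of bromo from an aromatic carbon two atoms from the ring nitrogen, so that site is not indifferent to this change. The earlier values could not show this, as compound 1 and compound 2 differ in more than one place; within this pair, bromo goes with the lower number, although compound 2 itself remains a weak inhibitor and the step is modest. No measurement at hand accounts for the size or direction of this step.

One pair does not settle whether the lower number belongs to bromo alone or would also appear with chloro, methyl or a nitrile at the same carbon on the dihydroxy core. Also open, from the compounds shown here alone, is whether the step keeps its size when the ethyl ester chain gives way to a carboxylic acid or a longer chain, or when the two hydroxy groups are replaced by methoxy groups.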